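Swapping a Spirocyclic Amide for a Bicyclic One

A few compounds are considered here, and "the series" means these few. Any claim that something is new, unique, unknown or untested is made for them only; others in the source may bear on it.

Compound 1 `O=C(C1CCC2(CCC2)CC1)N1CC(c2nc(-c3cccc(Cl)c3)no2)C1`: 1100 nM
Compound 2 `Cc1cccc(-c2noc(C3CN(C(=O)c4ccccc4F)C3)n2)c1`: > 10000 nM (a limit)

Among the measured compounds shown here, in an assay on HEK293 cells for positive allosteric modulation of metabotropic glutamate receptor 5 (Homo sapiens), read by FLIPR (on this read-out lower numbers stand for an effect already at smaller amounts and higher numbers for an effect only at larger amounts of compound), compound 1 gives 1100 nM, the only real number among the values shown. Compound 2 is reported only as a limit, (the limit of > 10000 nM in this assay, at which 1 of the 2 values shown sits). Compound 3 `O=C([C@H]1CC2CCC1C2)N1CC(c2nc(-c3cccc(Cl)c3)no2)C1` differs from compound 1 in one place: a group of 7 heavy atoms (7 carbon; 2 five-membered non-aromatic rings of carbon only) in place of a group of 9 heavy atoms (9 carbon; one four-membered non-aromatic ring of carbon only, one six-membered non-aromatic ring of carbon only), on a carbonyl carbon. For the measured compounds named here, no measured pair shows what such a swap of non-aromatic carbon rings does here, so a step of about the usual scatter, in either direction, is expected, the estimated step being a 1.4-fold higher number from compound 1 to compound 3 (0.13 log units; within the scatter). Compound 3 is therefore expected to give about 1500 nM, likely between 500 nM and 5000 nM.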

Compound 3, half-maximal effective concentration: 74 nM
Compound 3: the middle estimate sits 20-fold (1.31 log units) above what was measured; the measured number lies below the stated range.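

At this position, on a carbonyl carbon, the choice of non-aromatic carbon rings clearly matters: in this assay, the swap gives a 15-fold lower number from compound 1 to compound 3 (1.17 log units; beyond the scatter). Neither group has hydrogen-bond donors, hydrogen-bond acceptors or a net charge, so a change in the carbon rings alone can produce a large step. The group with fewer carbon atoms gives the lower number, so the larger group is not required here.

On these data alone, it remains open whether an amine or a carboxylic acid on this ring group would keep the lower number, and what the opposite arrangement at the defined stereocentre would give. The values shown offer no explanation for the step.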